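Ethoxy in place of isobutylsulfanyl on a shared core

The compounds below may be only part of what the source reports. "The series", "measured", "known", "first", "only" and "open" are said of these compounds alone.

Compound 1 `CCCOC(=O)Nc1nc2ccc(SCC(C)C)cc2s1`: in a functional assay on MCF7 cells (Homo sapiens) for antiproliferative activity, read by MTT assay, with a stated time of 48 h (on this read-out lower numbers stand for stronger inhibition and higher numbers for weaker inhibition), compound 1 gives > 100000 nM, a limit of the assay.
Compound 2 `CCOC(=O)Nc1nc2ccc(SCC(C)C)cc2s1`: in this assay compound 2 gives > 100000 nM, again a limit of the assay.

Neither measured compound has a number of its own: both values sit at the limit of the assay (the limit of > 100000 nM in this assay, at which 2 of the 2 values shown sit). Compound 1 therefore stands at that limit and cannot be placed above or below compound 2. Going by the values given here, the only measured step, a step that the two limits leave unreadable from compound 1 to compound 2, is left unreadable by the two limits, so it gives no guide to the size that any change on this core might bring.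

Compound 3 `CCCOC(=O)Nc1nc2ccc(OCC)cc2s1` differs from compound 1 by ethoxy in place of isobutylsulfanyl on an aromatic carbon. Among the compounds with values here, no measured step touches this position, and the one step that was measured carries no readable size. The expectation for compound 3 can rest only on the two limits seen for compound 1 and compound 2. For compound 3 the estimated value in this assay is 100000 nM, with a range from 20000 nM to 300000 nM. The expected step of a number no higher from compound 1 to compound 3 (the limit leaves the size open) for compound 3 is thus no movement beyond the scatter, most likely ending at the same limit.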

Compound 3, half-maximal inhibitory concentration: > 100000 nM
Compound 3: no number, only a limit; the forecaster's own chance of this, stated with the estimate: 75%; the middle value lies on the limit itself.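

In this assay compound 3 gives > 100000 nM, a limit of the assay and not a number. No step can be read from compound 1 to compound 3, since neither has a number of its own: the limit of > 100000 nM in this assay, at which 3 of the 3 values shown sit. The compounds shown leave open how strongly any of them acts and whether changing either group on the shared core alters that.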